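Working notes: from compound 2 to compound 3

This account rests on a few compounds, and the source may have more. Where it says the series, first, only, none or still open, it means among the compounds named here.

For the measured compounds named here, in an ADME assay on MT4 cells (Homo sapiens) for cytotoxicity, read by MTT assay (on this read-out higher numbers stand for lower toxicity in this test and lower numbers for higher toxicity in this test), compound 2 `O=C1c2ccccc2C(Cc2ccccc2)C(=O)N1O` gives 95000 nM and stands highest of the two numbers, over compound 1 `CCCCC1C(=O)N(O)C(=O)c2ccccc21` at 25400 nM as the only other measurement. The change to compound 3 `O=C1c2ccccc2C(CCc2ccccc2)C(=O)N1O` is benzyl in place of phenyl on a saturated chain carbon bound to a saturated ring carbon with benzyl in place of phenyl on a saturated chain carbon bound to a saturated ring carbon. Only a 3.7-fold higher number from compound 1 to compound 2 (0.57 log units; beyond the scatter) bears on it, a modest step at the same place but for a different exchange. No step beyond the scatter is therefore expected in this assay with a slight lean to a lower number. The expected step is a 1.6-fold lower number from compound 2 to compound 3 (0.20 log units; within the scatter) on this single precedent. For compound 3 the estimate is 60000 nM with an expected range from 25000 nM to 140000 nM.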

Compound 3, half-maximal cytotoxic concentration: 30000 nM
Compound 3: the middle estimate sits 2.0-fold (0.30 log units) above what was measured, within the range that was stated.
By their numbers in this assay, from the lowest: compounds 1 and 3 (each within the scatter of the next); then compound 2.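

In this assay, benzyl in place of phenyl on a saturated chain carbon bound to a saturated ring carbon reverses the direction of the earlier step at this place (a 3.2-fold lower number from compound 2 to compound 3 (0.50 log units; beyond the scatter)). Phenyl in place of ethyl on a saturated chain carbon, two bonds along the chain from a saturated ring carbon, leaves no separation (a 1.2-fold higher number from compound 1 to compound 3 (0.07 log units; within the scatter)), so only compound 2 stands apart among these three. Nothing at hand accounts for this. Going by these compounds, how a longer chain, or an amine or a carboxylic acid on the chain, would read remains open.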